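From 3,5-dimethoxyphenyl to 2,3-dimethoxyphenyl in the series

A few compounds are considered here, and "the series" means these few. Any claim that something is new, unique, unknown or untested is made for them only; others in the source may bear on it.

In a functional assay on HCT-116 cells (Homo sapiens) for antiproliferative activity, read by sulforhodamine B assay, with a stated time of 48 h (on this read-out higher numbers stand for weaker inhibition and lower numbers for stronger inhibition), compound 1 `COc1ccc(/C=C/C(=O)c2c(OC)cc(OC)cc2OCC=C(C)C)cc1` gives 7600 nM and compound 2 `COc1cccc(/C=C/C(=O)c2c(OC)cc(OC)cc2OCC=C(C)C)c1` gives 7700 nM. The step between them is a 1.0-fold higher number from compound 1 to compound 2 (0.01 log units; within the scatter). Compound 3 `COc1cc(/C=C/C(=O)c2c(OC)cc(OC)cc2OCC=C(C)C)cc(OC)c1` gives 3500 nM, the lowest of the three numbers. It is reached by two modest steps, a 2.2-fold lower number from compound 1 to compound 3 (0.34 log units; beyond the scatter) and a 2.2-fold lower number from compound 2 to compound 3 (0.34 log units; beyond the scatter).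

Compound 4 `COc1cc(OC)c(C(=O)/C=C/c2cccc(OC)c2OC)c(OCC=C(C)C)c1` has not yet been measured. It holds the same atoms as compound 3, joined differently: 2,3-dimethoxyphenyl in place of 3,5-dimethoxyphenyl on a double-bonded chain carbon bound to a double-bonded chain carbon. This places 2,3-dimethoxyphenyl in place of 3,5-dimethoxyphenyl on a double-bonded chain carbon bound to a double-bonded chain carbon.

Among the compounds with values here, no measured compound carries the 2,3-dimethoxyphenyl group, so the evidence is indirect. The step to compound 2 from compound 1 suggests that a changed methoxy position alone can leave the number unmoved, as a 1.0-fold higher number from compound 1 to compound 2 (0.01 log units; within the scatter) shows. Within the data shown here, the only step beyond the scatter, a 2.2-fold lower number from compound 2 to compound 3 (0.34 log units; beyond the scatter), is small and adds a methoxy group, whereas compound 4 keeps the same count of methoxy groups as compound 3. The series therefore gives no ground for expecting a large move in this assay, and any loss is expected to be slight. The expected step is a 1.4-fold higher number from compound 3 to compound 4 (0.15 log units; within the scatter). For compound 4 the estimated value is 5000 nM, with an expected range of 2000 nM to 12000 nM.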

Compound 4, half-maximal inhibitory concentration: 11700 nM
Beside the measured number, compound 4's estimate is 2.3-fold (0.37 log units) below it; the range from low to high includes it.
By their numbers in this assay, from the lowest: compound 3; then compounds 1, 2 and 4 (each within the scatter of the next).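

In this assay, within the data shown here, the two methoxy groups are kept and only their placement changes (a 3.3-fold higher number from compound 3 to compound 4 (0.52 log units; beyond the scatter)), so placement on this group alone can carry a step beyond the scatter, which the single methoxy shift among the earlier compounds did not show. The lower number of compound 3 therefore does not follow from the count of methoxy groups: compound 4 carries the same count yet stands level with the compounds that have one fewer (a 1.5-fold higher number from compound 2 to compound 4 (0.18 log units; within the scatter); a 1.5-fold higher number from compound 1 to compound 4 (0.19 log units; within the scatter)), both steps within the scatter, and so goes against any rule that adding a methoxy group lowers the number. No measurement on hand accounts for the difference between the 2,3-dimethoxyphenyl and 3,5-dimethoxyphenyl groups.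

Still open, from the compounds shown here alone, is whether the advantage of the 3,5-dimethoxyphenyl group extends to a 3,4,5-trimethoxyphenyl group, or survives with ethoxy, hydroxy or dimethylamino groups at the same places. Going by these compounds, all four compounds share one core and one 3-methylbut-2-enyl ether chain, so it also remains open whether the placement effect persists with a longer chain or a carboxylic acid on that part of the molecule.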